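Replacing cyclobutyl with 4-fluorophenyl on the core of compound 1

A few compounds are considered here, and "the series" means these few. Any claim that something is new, unique, unknown or untested is made for them only; others in the source may bear on it.

- compound 1 `C1CCC(C(CC2CCCCN2)C2CCC2)CC1`: > 3.33 h (a limit)
- compound 2 `C1CCC(CC(C2CCCC2)C2CCC2)NC1`: 0.85 h
- compound 3 `C1CCC(CC(C2CCCC2)C2CCCC2)NC1`: 0.833 h

All three values come from an ADME assay on microsomes from liver (Homo sapiens) for metabolic stability, read by LC-MS, using NADPH, with a stated time of 45 min, tested at 3 uM; a higher number here means that the compound lasts longer, a lower number that the compound disappears faster. Compound 1 gives > 3.33 h, which is a limit and not a number. Compound 4 `Fc1ccc(C(CC2CCCCN2)C2CCCCC2)cc1` carries 4-fluorophenyl in place of cyclobutyl on a saturated chain carbon bound to a saturated chain carbon and a saturated ring carbon. Within the data shown here, no measured step brings in an aromatic ring, so the evidence is indirect. The closest swap of cyclobutyl, a 1.0-fold lower number from compound 2 to compound 3 (0.01 log units; within the scatter), stayed within the scatter. The swap of cyclohexyl, an at least 3.9-fold lower number from compound 1 to compound 2 (0.59 log units; beyond the scatter), went beyond it, but compound 4 keeps that group. The expected step is small and downward, possibly within the scatter: an at least 1.3-fold lower number from compound 1 to compound 4 (0.12 log units; that floor lies within the scatter). For compound 4 the estimated half-life is 2.5 h, with an expected range of 0.8 h to 6 h.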

Compound 4, half-life: 1.32 h
For compound 4 the middle estimate is 1.9-fold (0.28 log units) above the measured one; measured number inside the range.
By their numbers in this assay, from the lowest: compounds 3, 2 and 4 (each within the scatter of the next). At a limit, above all of these: compound 1.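

In this assay, 4-fluorophenyl in place of cyclobutyl gives an at least 2.5-fold lower number from compound 1 to compound 4 (0.40 log units; beyond the scatter). Among these compounds, this is the first aromatic ring at this place and the first change of cyclobutyl that goes beyond the scatter, unlike the cyclopentyl swap, a 1.0-fold lower number from compound 2 to compound 3 (0.01 log units; within the scatter). The size of the new step is only a floor, set by compound 1: the limit of > 3.33 h in this assay, at which 1 of the 4 values shown sits.

Left open is whether the loss follows the aromatic ring or the fluorine, which an unsubstituted phenyl would separate. Also open, as far as these compounds go, is how an amine or a carboxylic acid at this place would behave.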